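The source may hold more compounds than are shown below. What is called first, only, known or untested is meant among the compounds shown, and "the series" means these compounds.

Series so far, in a functional assay on MCF7 cells (Homo sapiens) for cytotoxicity, read by MTT assay, with a stated time of 72 h; a lower number here means a stronger inhibitor, a higher number a weaker inhibitor:
- compound 1 `CN(C)c1ccc(C=C2C(=O)N(c3ccc(Cl)cc3)N(c3ccc(Cl)cc3)C2=O)cc1`: > 128000 nM (a limit)
- compound 2 `COc1cccc(C=C2C(=O)N(c3ccc(Cl)cc3)N(c3ccc(Cl)cc3)C2=O)c1OC`: 11900 nM

Going by the values given here, compound 2 holds the only actual number in this assay, and the one other result is a limit. Compound 3 `COc1ccccc1C=C1C(=O)N(c2ccc(Cl)cc2)N(c2ccc(Cl)cc2)C1=O` is the next case, going from 2,3-dimethoxyphenyl to 2-methoxyphenyl: hydrogen in place of methoxy on an aromatic carbon, ortho to a methoxy group.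

Among the compounds with values here, only one measured step bears on this, and only indirectly: an at least 10-fold lower number from compound 1 to compound 2 (1.03 log units; beyond the scatter). It exchanges 4-(dimethylamino)phenyl for 2,3-dimethoxyphenyl, a much larger change than the loss of one methoxy. Compound 1 enters that step as the limit of > 128000 nM in this assay, at which 1 of the 2 values shown sits, so its true size is open. Within the data shown here, the step shows that the number can move with the group at this place, but no measured step removes a single methoxy. Among the measured compounds shown here, compound 3 keeps the 2-methoxy group, so no step clearly beyond the scatter is expected, with a slight lean to a higher number. The expected change is a 1.5-fold higher number from compound 2 to compound 3 (0.18 log units; within the scatter). For compound 3 the estimate is 18000 nM, with an expected range of 6000 nM to 60000 nM.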

Compound 3, half-maximal inhibitory concentration: 26300 nM
Compound 3: the middle estimate sits 1.5-fold (0.16 log units) below what was measured; the measured number falls inside the stated range.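

In this assay, going by these compounds alone, this is the first measured step that removes a single methoxy from the ring: a 2.2-fold higher number from compound 2 to compound 3 (0.34 log units; beyond the scatter). The methoxy on the aromatic carbon ortho to a methoxy group therefore has a modest but readable bearing on the number, and the second methoxy is not needed to stay clear of the 4-(dimethylamino)phenyl result, as the other new step shows: an at least 4.8-fold lower number from compound 1 to compound 3 (0.68 log units; beyond the scatter). Compound 1 enters that step only as a limit, so the step gives a bound and not a size: the limit of > 128000 nM in this assay, at which 1 of the 3 values shown sits.

The compounds shown leave open what the remaining 2-methoxy group contributes, and whether a plain phenyl group would lie further up, or whether a hydroxyl group or a fluorine atom in place of the lost methoxy would hold the number of compound 2. Also open, on these data alone, is whether the limit of compound 1 belongs to the dimethylamino group itself or to the wider change of ring pattern, which a single step cannot separate here.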